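Swapping an amide for a sulfone on the shared core

A few compounds are considered here, and "the series" means these few. Any claim that something is new, unique, unknown or untested is made for them only; others in the source may bear on it.

Measured so far:
compound 1 `CCN(CC)C(=O)c1ccc(S(=O)(=O)N2CCC[C@@H](C(=O)N3CCC(F)(F)CC3)C2)cc1` – 70 nM
compound 2 `CCN(CC)S(=O)(=O)c1ccc(S(=O)(=O)N2CCC[C@@H](C(=O)N3CCC(C(F)F)CC3)C2)cc1` – 420 nM

In a functional assay on MIA PaCa-2 cells (Homo sapiens) for inhibition, read by MTT assay, with a stated time of 7 days (a lower number here means a stronger inhibitor, a higher number a weaker inhibitor), compound 1 gives 70 nM, the lowest of the two numbers shown. Compound 2 gives 420 nM, a gap beyond the scatter; the two structures differ in more than one place, so nothing is known about either change on its own. Compound 3 `CC(C)CS(=O)(=O)c1ccc(S(=O)(=O)N2CCC[C@@H](C(=O)N3CCC(F)(F)CC3)C2)cc1` carries isobutylsulfonyl in place of diethylcarbamoyl on an aromatic carbon. Among the measured compounds shown here, with no single-change step measured, the expected step from compound 1 to compound 3 is a modest loss, a 2.1-fold higher number from compound 1 to compound 3 (0.33 log units; beyond the scatter). Compound 3 is therefore estimated at 150 nM, within 50 nM to 500 nM.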

Compound 3, half-maximal inhibitory concentration: 80 nM
Compound 3: the middle estimate sits 1.9-fold (0.27 log units) above what was measured; low and high end bracket the measured number.
By their numbers in this assay, from the lowest: compounds 1 and 3 (each within the scatter of the next); then compound 2.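

In this assay, isobutylsulfonyl in place of diethylcarbamoyl on an aromatic carbon gives a 1.1-fold higher number from compound 1 to compound 3 (0.06 log units; within the scatter). This single change, with the rest of the shared core held fixed, shows that this position tolerates a sulfone in place of the amide without a measurable change in the number. No measured evidence bears on why the two groups read alike.

Still open, from the compounds shown here alone, is whether a shorter chain such as methylsulfonyl, or a ring-bearing group such as cyclopropylsulfonyl, would read the same. A carboxylic acid or an amine at this position also remains untested in the compounds shown.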